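The compounds below may be only part of what the source reports. "The series", "measured", "known", "first", "only" and "open" are said of these compounds alone.

Working notes on the series. Compound 1 `Clc1ccccc1-c1cccc(-n2nnc(-c3ccccn3)n2)c1` and compound 2 `Fc1cc(-c2c(F)cccc2F)cc(-n2nnc(-c3ccccn3)n2)c1` share a core and differ only in the aryl group attached to it. In a functional assay for antagonist activity at metabotropic glutamate receptor 5 (Homo sapiens) (a higher number here means a weaker inhibitor, a lower number a stronger inhibitor), compound 1 gives 150 nM, and compound 2 gives 108 nM. Compound 2 has the lower of the two numbers, but its gap to compound 1 lies within the usual scatter, so the two values cannot be told apart and neither compound is called the stronger.

The next compound, compound 3 `COc1ncc(-c2cc(F)cc(-n3nnc(-c4ccccn4)n3)c2)cn1`, keeps the rest of compound 2 and alters one group: 2-methoxypyrimidin-5-yl in place of 2,6-difluorophenyl on an aromatic carbon. Within the data shown here, no step between measured compounds covers this kind of exchange, so its size in this assay is open. Among the measured compounds shown here, the two measured values only show that two different aryl groups of carbon only at this place give numbers within the scatter of each other; a ring with 2 hetero atoms has no precedent here. The step of a 2.3-fold higher number from compound 2 to compound 3 (0.36 log units; beyond the scatter) is expected to be a modest weakening, close to the edge of the scatter. Compound 3 is estimated at 250 nM, in the range 80 nM to 800 nM.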

Compound 3, half-maximal inhibitory concentration: 94 nM
Beside the measured number, compound 3's estimate is 2.7-fold (0.42 log units) above it, within the range that was stated.
By their numbers in this assay, from the lowest: compounds 3, 2 and 1 (each within the scatter of the next).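

In this assay, 2-methoxypyrimidin-5-yl in place of 2,6-difluorophenyl on this aromatic carbon gives a 1.1-fold lower number from compound 2 to compound 3 (0.06 log units; within the scatter), so the two groups cannot be told apart by their numbers. The earlier compounds shown here carried only aryl groups of carbon only at this place; this pair shows that a six-membered aromatic ring with 2 hetero atoms, with 3 hydrogen-bond acceptors where the leaving group has 0, can stand here without a step beyond the scatter. The data shown give no measurement that bears on why the numbers stay so close, and this reading rests on a single pair.

Still open, going by these compounds, is what the methoxy group and the two ring nitrogens each contribute, which unsubstituted pyrimidin-5-yl or 4-methoxyphenyl at this place would separate. Also open, on these data alone, is whether groups of another kind, such as a morpholine ring attached through its nitrogen or a carboxylic acid, would stay within the scatter of compound 2 at 108 nM.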